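The compounds below may be only part of what the source reports. "The series", "measured", "known", "first", "only" and "open" are said of these compounds alone.

In a functional assay on Bel-7402 cells (Homo sapiens) for inhibition, read by MTT assay, with a stated time of 24 h, tested at 1 ug/mL (a lower number here means less inhibition of growth, a higher number more inhibition of growth at the concentration tested), compound 1 (`O=C(CCCCC(S)CCS)Nc1ccc(Cl)cc1`) gives 0.27% and compound 2 (`O=C(CCCCC(S)CCS)Nc1ccc([N+](=O)[O-])c(C(F)(F)F)c1`) gives 0.68%. Compound 2 therefore stands level with compound 1, as the two numbers lie within the usual scatter of such measurements. Both are close to no growth inhibition at all.

Compound 3 (`O=C(CCCCC(S)CCS)Nc1ccc([N+](=O)[O-])cc1`) has not yet been measured. It differs from compound 2 by a single change, hydrogen in place of trifluoromethyl on an aromatic carbon, ortho to a nitro group. Within the data shown here, no measured pair differs in one place only, so the data offer no direct guide to the size of this change. Expectation rests on the two measured compounds alone. The expected step, a number 0.1 percentage points lower from compound 2 to compound 3 (within the scatter), stays within the scatter, with no direction favoured. In this assay, the estimate for compound 3 is 0.6%, with an expected range from 0.1% to 6%.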

Compound 3, percent growth inhibition at one concentration: 1.73%
Beside the measured number, compound 3's estimate is 1.1 percentage points below it; low and high end bracket the measured number.
By their numbers in this assay, from the lowest: compounds 1, 2 and 3 (each within the scatter of the next).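

Replacing trifluoromethyl with hydrogen on this aromatic carbon, ortho to a nitro group, gives a number 1.1 percentage points higher from compound 2 to compound 3 (within the scatter) in this assay, so compound 2 and compound 3 stand level and the trifluoromethyl group makes no difference that this read-out can detect. Nitro in place of chloro gives a number 1.5 percentage points higher from compound 1 to compound 3 (within the scatter), so that change cannot be told apart from scatter either, and all three compounds remain close to no growth inhibition at the single concentration tested. Nothing available bears on why these compounds behave this way.

The compounds shown leave open whether an amine or a methoxy group on this aromatic carbon would bring real growth inhibition. They also leave open whether a longer chain on the shared core would do so, and how any of these compounds would behave at a higher concentration.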